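Replacing 2-methoxyethynyl with 3-pentyloxiran-2-yl on the shared core

This account rests on a few compounds, and the source may have more. Where it says the series, first, only, none or still open, it means among the compounds named here.

Of the compounds shown here, two on one shared core have been measured so far. In a functional assay on L1210 cells (Mus musculus) for inhibition (on this read-out lower numbers stand for stronger inhibition and higher numbers for weaker inhibition), compound 1 (`CCCCCC#C[C@]1(C)O[C@@H]2OC(=O)N(C(=O)CCl)[C@@H]2CC1=O`) gives 32000 nM and compound 2 (`COC#C[C@@]1(C)O[C@@H]2OC(=O)N(C(=O)CCl)[C@@H]2CC1=O`) gives 74000 nM on the same read-out. Compound 2 thus holds the higher of the two numbers, and its gap to compound 1 lies beyond the usual scatter.

Compound 3 (`CCCCCC1OC1[C@@]1(C)O[C@@H]2OC(=O)N(C(=O)CCl)[C@@H]2CC1=O`) differs from compound 2 in one place, with 3-pentyloxiran-2-yl in place of 2-methoxyethynyl on a saturated ring carbon. Within the data shown here, no measured pair shows this exchange directly, so the expectation has little to rest on. Its main guide is compound 1 at 32000 nM as the lower of the two numbers on this core. On that basis, a modest step toward a lower number is expected in this assay and is estimated as a 2.5-fold lower number from compound 2 to compound 3 (0.39 log units; beyond the scatter) on this read-out. For compound 3 the estimate is 30000 nM with an expected range from 10000 nM to 80000 nM.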

Compound 3, half-maximal inhibitory concentration: 193000 nM
Beside the measured number, compound 3's estimate is 6.4-fold (0.81 log units) below it, outside the stated range (above it).
By their numbers in this assay, from the lowest: compound 1; then compound 2; then compound 3.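

The change from 2-methoxyethynyl to 3-pentyloxiran-2-yl on the saturated ring carbon next to the ring oxygen gives a 2.6-fold higher number from compound 2 to compound 3 (0.42 log units; beyond the scatter) in this assay, the first view of this position without a triple bond. The number here therefore moves upward with a group that has more heavy atoms, so heavy-atom count alone does not set the order among these three compounds: compound 1, compound 2 and compound 3 run from the lowest number to the highest, with compound 3 at 193000 nM. No measurement at hand bears on why the number rises with this exchange.

Going by these compounds, what remains open is which feature of the entering group goes with the higher number, the three-membered ring with its oxygen or the loss of the triple bond. A plain hexyl chain, a chain ending in a hydroxyl group or an amine at the same ring carbon would help separate these features, and all three compounds leave open how far the number at this position can fall below that of compound 1, 32000 nM.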